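Swapping methyl for methoxy on a methylsulfonyl-bearing aniline

A few compounds are considered here, and "the series" means these few. Any claim that something is new, unique, unknown or untested is made for them only; others in the source may bear on it.

Of the compounds shown here, two of one family have been tested in an assay on CHO cells for binding affinity to Alpha-2C adrenergic receptor (Homo sapiens), read by radioligand binding; on this read-out higher numbers stand for weaker inhibition and lower numbers for stronger inhibition. Compound 1, `COc1ccc(SC)c(NCC2=NCCN2)c1`, gives 603 nM in this assay. Compound 2, `Cc1ccc(S(C)(=O)=O)c(NCC2=NCCN2)c1`, is reported only as a limit of this assay, < 5020 nM, so its true value is not pinned down; the limit of < 5020 nM in this assay, at which 1 of the 2 values shown sits, marks that situation. Compound 3, `COc1ccc(S(C)(=O)=O)c(NCC2=NCCN2)c1`, has not yet been measured. It differs from compound 2 by methoxy in place of methyl on an aromatic carbon. Compound 1 also carries a methoxy group and sits at a measured value, while compound 2 carries methyl and sits at a limit, so a step in this assay toward stronger inhibition is expected, with a step that the limit leaves unreadable from compound 2 to compound 3 as the estimated size. On that basis compound 3 is expected to give about 1500 nM in this assay, most likely between 400 nM and 6000 nM.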

Compound 3, inhibition constant: < 5020 nM
Compound 3: only a limit was reported (the forecaster's own chance of this, stated with the estimate: 30%); the middle value lies beyond the limit too.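

In this assay, compound 3 is reported only as a limit, < 5020 nM, so no step from compound 1 or compound 2 to compound 3 can be read: the limit of < 5020 nM in this assay, at which 2 of the 3 values shown sit.

Going by these compounds, whether methoxy in place of methyl, or methylsulfonyl in place of methylsulfanyl, shifts the value in this assay stays open.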